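A few compounds are considered here, and "the series" means these few. Any claim that something is new, unique, unknown or untested is made for them only; others in the source may bear on it.

Compound 1 `COc1ccc(C(O)C2OC(=O)c3c(OC)cc(OC)cc32)cc1` sits at a limit in a functional assay on RAW264.7 cells (Mus musculus) for inhibition, read by Griess assay, with stated times of 1 h and 24 h (on this read-out lower numbers stand for stronger inhibition and higher numbers for weaker inhibition), rather than at a number, giving > 10000 nM; this is the limit of > 10000 nM in this assay, at which 1 of the 2 values shown sits. Compound 2 `C=CCCOc1ccc(C(O)C2OC(=O)c3c(OC)cc(OC)cc32)cc1` in this assay gives 1330 nM, the only number shown in the set. Within the data shown here, the one measured step, an at least 7.5-fold lower number from compound 1 to compound 2 (0.87 log units; beyond the scatter), is the sole guide to the next change, and it came from a change at the same place. Compound 3 `COc1cc(OC)c2c(c1)C(C(O)c1ccc(OCc3ccc(OC(F)(F)F)cc3)cc1)OC2=O` differs from compound 2 by 4-(trifluoromethoxy)phenyl in place of allyl on a saturated chain carbon bound to an oxygen on an aromatic ring. Since the earlier step at this position lowered the number, compound 3 is expected to move further in the same direction, or to stay within the scatter, rather than to rise. The step from compound 2 is expected to be a 1.9-fold lower number from compound 2 to compound 3 (0.28 log units; within the scatter). Compound 3 is therefore estimated at 700 nM in this assay, within a range from 200 nM to 3000 nM.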

Compound 3, half-maximal inhibitory concentration: 8140 nM
Estimate against measurement, compound 3: 12-fold (1.07 log units) below; measured number outside the range, above it.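

Placing 4-(trifluoromethoxy)phenyl instead of allyl on the saturated chain carbon bound to an oxygen on an aromatic ring gave a 6.1-fold higher number from compound 2 to compound 3 (0.79 log units; beyond the scatter), so the gain seen with allyl does not extend to every group at this place. Set against hydrogen at the same place, the aromatic group gives an at least 1.2-fold lower number from compound 1 to compound 3 (0.08 log units; that floor lies within the scatter), and this floor does not show that it improves on hydrogen. Compound 1 remains a limit rather than a number: the limit of > 10000 nM in this assay, at which 1 of the 3 values shown sits.

The compounds shown leave open whether the higher number goes with the aromatic ring itself or with the trifluoromethoxy group it carries. Going by these compounds, what an unsubstituted phenyl, a longer carbon chain or an amine would give at this place also remains open.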